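The source may report more compounds than this note shows. Statements on the series, on what has been measured and on what is new or still open speak of the compounds shown alone.

Measured so far:
compound 1, `Cc1ccccc1-c1nn(Cc2ccc(F)cc2)cc1CNCCN1CCN(C)CC1`: > 20000 nM
compound 2, `Cc1ccccc1-c1nn(-c2ccc(F)cc2F)cc1CNCCN1CCN(C)CC1`: > 20000 nM

Both results come from an ADME assay on Huh-7 cells (Homo sapiens) for cytotoxicity; on this read-out lower numbers stand for higher toxicity in this test and higher numbers for lower toxicity in this test. In this assay compound 1 reaches only a limit, > 20000 nM. For compound 2 the result is likewise a limit, > 20000 nM. The step that the two limits leave unreadable from compound 1 to compound 2 cannot be read, because both values sit at the limit of > 20000 nM in this assay, at which 2 of the 2 values shown sit. Compound 2 therefore stands at the edge of what this assay reports, without a number of its own.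

Compound 3, `Cc1ccccc1-c1nn(-c2ccc(Br)cc2)cc1CNCCN1CCN(C)CC1`, has not yet been measured. It differs from compound 2 in one place: 4-bromophenyl in place of 2,4-difluorophenyl on an aromatic nitrogen. For the measured compounds named here, the only measured step, from compound 1 to compound 2, exchanged 4-fluorobenzyl for 2,4-difluorophenyl on an aromatic nitrogen, and its size is not readable. Going by the values given here, no measured step covers the exchange of one phenyl group for another at that position, so the only guide is that both measured compounds share (the limit of > 20000 nM in this assay, at which 2 of the 2 values shown sit). On that basis compound 3 is expected to stay at the limit, a step that the limit leaves unreadable from compound 2 to compound 3. The estimate for compound 3 is 25000 nM, within 12000 nM to 60000 nM.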

Compound 3, half-maximal cytotoxic concentration: 9600 nM
Estimate against measurement, compound 3: 2.6-fold (0.42 log units) above; measured number outside the range, below it.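

In this assay, for the compounds shown here, compound 3 gives the first value with a number of its own, which shows that the group on this aromatic nitrogen can move the read-out towards higher toxicity in this test: 4-bromophenyl in place of 2,4-difluorophenyl gives an at least 2.0-fold lower number from compound 2 to compound 3 (0.31 log units; beyond the scatter). Set against the benzyl-linked group, 4-bromophenyl in place of 4-fluorobenzyl gives an at least 2.0-fold lower number from compound 1 to compound 3 (0.31 log units; beyond the scatter), so the same group stands apart from both earlier substituents, and each step gives only a minimum size. Compound 1 and compound 2 both remain at a limit of the assay, so neither can be ranked against the other: the limit of > 20000 nM in this assay, at which 2 of the 3 values shown sit.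

The compounds shown leave open whether the lower number goes with the bromine atom itself or with the absence of the two fluorine atoms, and a plain phenyl or a 4-chlorophenyl group on this nitrogen would help to separate the two. They also leave open whether a 4-bromobenzyl group would give a number like that of compound 3 or would stay at the limit, as the 4-fluorobenzyl group of compound 1 does.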